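Sulfonyl in place of furanylmethyl on the ring nitrogen

A few compounds are considered here, and "the series" means these few. Any claim that something is new, unique, unknown or untested is made for them only; others in the source may bear on it.

Compound 1 `COc1ccc([C@H]2CC(=O)N(c3ccccc3N)C2)cc1OC1CCCC1` and compound 2 `COc1ccc([C@H]2CC(=O)N(c3cccc(NCc4ccoc4)c3)C2)cc1OC1CCCC1` share one core and were both tested in a functional assay on HEK293 cells (Homo sapiens) for cytotoxicity; on this read-out lower numbers stand for higher toxicity in this test and higher numbers for lower toxicity in this test. For compound 1 the result of > 10000 nM is a limit of the assay rather than a number. For compound 2 the result of > 10000 nM is likewise a limit. Compound 2 therefore stands at the limit of > 10000 nM in this assay, at which 2 of the 2 values shown sit. Compound 3 `COc1ccc([C@H]2CC(=O)N(c3cccc(NS(=O)(=O)c4cccc(C)c4)c3)C2)cc1OC1CCCC1` carries (3-methylphenyl)sulfonyl in place of (furan-3-yl)methyl on a nitrogen on an aromatic ring. Among the compounds with values here, no step between measured compounds is known, so the expected change in this assay is none beyond the usual scatter, namely a step that the limit leaves unreadable from compound 2 to compound 3. Compound 3 is accordingly estimated at 15000 nM, most likely reported once more only as a limit.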

Compound 3, half-maximal cytotoxic concentration: > 10000 nM
Compound 3 gave a limit, no number; the forecaster's own chance of this, stated with the estimate: 80%; the middle value does not contradict the limit.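

In this assay compound 2 and compound 3 both give only a limit of the assay, and no step can be read between them. The compounds shown leave open whether (3-methylphenyl)sulfonyl in place of (furan-3-yl)methyl changes this read-out at all.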